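Expected cytotoxicity of a nitrophenyl analogue in HeLa cells

This account rests on a few compounds, and the source may have more. Where it says the series, first, only, none or still open, it means among the compounds named here.

Compound 1, `O=C(/C=C\c1ccccc1)N1N=C(c2ccncc2)OC1c1c[nH]c2ccccc12`: > 30 ug/mL
Compound 2, `O=C(/C=C\c1ccc(O)cc1)N1N=C(c2ccncc2)OC1c1c[nH]c2ccccc12`: > 30 ug/mL

In an ADME assay on HeLa cells (Homo sapiens) for cytotoxicity, read by MTT assay, with a stated time of 72 h (a higher number here means a weaker inhibitor of growth, a lower number a stronger inhibitor of growth), compound 1 gives > 30 ug/mL, which is a limit of the assay rather than a number. Compound 2 gives > 30 ug/mL in this assay, again a limit and not a number. The step that the two limits leave unreadable from compound 1 to compound 2 is therefore unreadable, since both of its ends sit at the limit of > 30 ug/mL in this assay, at which 2 of the 2 values shown sit. Compound 2 thus stands at the limit of this assay, and nothing in the measured numbers places it above or below compound 1.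

Compound 3, `O=C(/C=C\c1ccccc1[N+](=O)[O-])N1N=C(c2ccncc2)OC1c1c[nH]c2ccccc12`, differs from compound 2 by 2-nitrophenyl in place of 4-hydroxyphenyl on a double-bonded chain carbon bound to a double-bonded chain carbon. Going by the values given here, the only measured step that bears on a change at this position is the step from compound 1 to compound 2, and its size cannot be read. Among the compounds with values here, no measured step, then, supports an expectation of a shift beyond the scatter in this assay, and compound 3 is expected to remain at the limit like compound 2. The estimate for compound 3 is 30 ug/mL, expected to fall between 15 ug/mL and 60 ug/mL. The step of a number no higher from compound 2 to compound 3 (the limit leaves the size open) is expected to be no larger than the scatter.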

Compound 3, concentration for 50% growth inhibition: > 30 ug/mL
Compound 3: only a limit was reported (the forecaster's own chance of this, stated with the estimate: 80%); the middle value sits exactly at the limit.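

Compound 3 gives > 30 ug/mL in this assay, which is a limit of the assay and not a number. No new step can be read for compound 1, compound 2 or compound 3, since all three sit at the same limit: the limit of > 30 ug/mL in this assay, at which 3 of the 3 values shown sit.

The compounds shown leave open how far each lies beyond that limit, and whether the 2-nitrophenyl or 4-hydroxyphenyl group changes growth inhibition at all.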